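The source may hold more compounds than are shown below. What is called first, only, known or untested is meant among the compounds shown, and "the series" means these compounds.

Measured so far:
Compound 1, `CCn1c(=O)c2nc[nH]c2n(CC)c1=O`, with 1770 nM in an assay on HEK293 cells for binding affinity to adenosine receptor A2b (Homo sapiens), read by radioligand binding; on this read-out lower numbers stand for stronger inhibition and higher numbers for weaker inhibition
Compound 2, `COCn1c(=O)c2c(ncn2C)n(C)c1=O`, with 14000 nM in this assay

Of these two numbers, compound 2 gives the higher one, 14000 nM, and the gap to compound 1 lies beyond the scatter of repeated measurements. The next compound builds on compound 2. Compound 3, `CC(=O)OCCn1c(=O)c2c(ncn2C)n(C)c1=O`, differs from it only in one place: acetoxymethyl in place of methoxy on a saturated chain carbon bound to an aromatic nitrogen. Within the data shown here, no measured pair shows a change of this kind, so there is nothing in the numbers to set its direction. The expectation is therefore a step of modest size, with no strong reason to favor stronger or weaker binding; the step that this estimate means, a 1.4-fold lower number from compound 2 to compound 3 (0.15 log units; within the scatter), is expected to stay within the usual scatter. For compound 3 the estimated value in this assay is 10000 nM, within a range from 3000 nM to 40000 nM.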

Compound 3, inhibition constant: 8710 nM
The estimate for compound 3 lay 1.1-fold (0.06 log units) above the measured number; measured number inside the range.
By their numbers in this assay, from the lowest: compound 1; then compounds 3 and 2 (each within the scatter of the next).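

Putting acetoxymethyl in place of methoxy on a saturated chain carbon bound to an aromatic nitrogen gives, in this assay, a 1.6-fold lower number from compound 2 to compound 3 (0.21 log units; within the scatter). The two numbers cannot be told apart, so this place accepts a group of 5 heavy atoms, with a double bond outside aromatic rings and 2 hydrogen-bond acceptors, with no readable effect on the number compared with the 2 heavy atoms and 1 acceptor of methoxy. Nothing available explains why the number holds steady across this change.

This reading rests on a single pair, so it cannot say how far the place stays this accepting. An amine, a carboxylic acid or a longer chain in the same place could still move the number beyond the scatter, and the compounds shown do not tell whether it would.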